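Cytotoxicity notes on the series, step to compound 4

A few compounds are considered here, and "the series" means these few. Any claim that something is new, unique, unknown or untested is made for them only; others in the source may bear on it.

Three members of the series have been measured for cytotoxicity. Compound 1 `CCN(CC)CN1C(=O)/C(=N/NC(=S)Nc2ccccc2)c2cc(Cl)ccc21` gives 100000 nM in an ADME assay on HEL cells (Homo sapiens) for cytotoxicity; on this read-out higher numbers stand for lower toxicity in this test and lower numbers for higher toxicity in this test. Compound 2 `CCN(CC)CN1C(=O)/C(=N/NC(=S)Nc2ccc(C)cc2)c2ccccc21` gives 100000 nM in this assay, and compound 3 `CCN(CC)CN1C(=O)/C(=N/NC(=S)Nc2ccc(OC)cc2)c2cc(Cl)ccc21` gives 100000 nM in this assay. Compound 3 thus stands level with compounds 1 and 2 at the digits shown, with no difference beyond the scatter in either direction. Among the measured compounds shown here, the only single-point step among the measured compounds is no change at the digits printed from compound 1 to compound 3 (within the scatter), which shows that adding methoxy on an aromatic carbon left the read-out unchanged.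

Compound 4 `CCN(CC)CN1C(=O)/C(=N/NC(=S)Nc2ccc(C)cc2)c2cc(Cl)ccc21` differs from compound 3 by methyl in place of methoxy on an aromatic carbon, a change on an aromatic carbon of a six-membered aromatic ring of carbon only, para to a large group. For the measured compounds named here, the one step that bears on this position, from compound 1 to compound 3, was flat, and compound 2, which already carries methyl at this position on a core without the chlorine, sits at the same level as compounds 1 and 3. Nothing here points to movement, so the expected step is no change at the digits printed from compound 3 to compound 4 (within the scatter), none beyond the scatter. Compound 4 is therefore estimated at 100000 nM in this assay, with a range from 50000 nM to 200000 nM.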

Compound 4, minimum cytotoxic concentration: 100000 nM
For compound 4 middle estimate and measured number coincide at the digits printed, and the stated range covers the measured number.
By their numbers in this assay, from the lowest: compounds 1, 2, 3 and 4 (each within the scatter of the next).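

In this assay, methyl in place of methoxy on this aromatic carbon gives no change at the digits printed from compound 3 to compound 4 (within the scatter), so on the core of compound 1 this position now has hydrogen, methoxy and methyl all reading alike. Methyl in place of hydrogen gives no change at the digits printed from compound 1 to compound 4 (within the scatter), a direct reading of methyl against hydrogen that the earlier compounds did not offer, since compound 2 lacked a partner differing in one place. Chloro in place of hydrogen on the other aromatic ring gives no change at the digits printed from compound 2 to compound 4 (within the scatter), the first single-place reading for the chloro group in the series.

Going by these compounds, whether an amine, a carboxylic acid or a longer chain on this aromatic carbon would read at the same level remains open, as does the effect of changes elsewhere on the shared core. No supporting evidence bears on these results, so the readings stand without an explanation.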